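This account rests on a few compounds, and the source may have more. Where it says the series, first, only, none or still open, it means among the compounds named here.

Measured in an assay on C6 cells for displacement of a labelled ligand from Translocator protein (Rattus norvegicus), read by scintillation counting, with a stated time of 2 h; a higher number here means a weaker inhibitor, a lower number a stronger inhibitor:
compound 1 `CCc1cc(CC)n2nc(-c3ccc(OC)cc3)c(CC(=O)N(CC)C(C)(C)C)c2n1` gives 59.1 nM
compound 2 `CCc1cc(CC)n2nc(-c3ccc(OC)cc3)c(CC(=O)N(C)c3ccccc3)c2n1` gives 6.44 nM

Among the compounds with values here, compound 2 holds the lowest number of the two; the only neighbour is compound 1, and the step of a 9.2-fold lower number from compound 1 to compound 2 (0.96 log units; beyond the scatter) is the sole measured change at the amide nitrogen. Within the data shown here, compound 3 `CCc1cc(CC)n2nc(-c3ccc(OC)cc3)c(CC(=O)N3CCCC3)c2n1` differs from compound 2 by pyrrolidin-1-yl in place of methyl(phenyl)amino on a carbonyl carbon, again on the carbonyl carbon, so that step is the one comparison that bears on it. Removing the aromatic ring is expected to move the number back toward compound 1, by a 4.7-fold higher number from compound 2 to compound 3 (0.67 log units; beyond the scatter), a rise beyond the scatter. Compound 3 is estimated at 30 nM, between 8 nM and 120 nM.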

Compound 3, inhibition constant in the Translocator protein assay: 127 nM
For compound 3 the middle estimate is 4.2-fold (0.63 log units) below the measured one, outside the stated range (above it).
By their numbers in the Translocator protein assay, from the lowest: compound 2; then compound 1; then compound 3.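

Compound 3 is the weakest of the three in the Translocator protein assay, with a 20-fold higher number from compound 2 to compound 3 (1.29 log units; beyond the scatter) and a 2.1-fold higher number from compound 1 to compound 3 (0.33 log units; beyond the scatter). Removing the aromatic ring therefore does not simply return the number to that of compound 1: pyrrolidin-1-yl on the carbonyl carbon does worse than the open-chain group. In a physicochemical assay for lipophilicity, read by HPLC, at pH 7.5 (on this read-out lower numbers stand for lower lipophilicity and higher numbers for higher lipophilicity), compound 2 gives 3.11 and compound 3 gives 2.72. The partition coefficient also separates compound 2 and compound 3, though two compounds cannot tie it to the change in binding: the measured partition coefficient of compound 2, 3.11, and of compound 3, 2.72, a number 0.39 log units lower (beyond the scatter)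

Going by these compounds, it remains open whether the phenyl or the methyl of methyl(phenyl)amino accounts for the low number of compound 2. On these data alone, whether a piperidine or morpholine amide would follow compound 3 is also open.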